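Chloro for nitrile on the aryl amine of compound 3

This account rests on a few compounds, and the source may have more. Where it says the series, first, only, none or still open, it means among the compounds named here.

In a functional assay on thoracic aorta (Rattus norvegicus) for inhibition (on this read-out lower numbers stand for an effect already at smaller amounts and higher numbers for an effect only at larger amounts of compound), three close analogues of one shared core have been measured. Compound 1 `CC1(C)CC(NC(=S)Nc2cccc(C#N)c2)c2cc(NS(C)(=O)=O)ccc2O1` gives 9800 nM, compound 2 `CC1(C)CC(NC(=S)Nc2cccc(Cl)c2)c2cc(NS(C)(=O)=O)ccc2O1` gives 9800 nM, and compound 3 `CC1(C)CC(NC(=O)Nc2cccc(C#N)c2)c2cc(NS(C)(=O)=O)ccc2O1` gives 9300 nM. Compound 3 thus holds the lowest of the three numbers, but its gaps to compound 1 and to compound 2 both lie within the usual scatter, so the three compounds cannot be told apart on these figures. Compound 4 `CC1(C)CC(NC(=O)Nc2ccc(Cl)cc2)c2cc(NS(C)(=O)=O)ccc2O1` has not yet been measured; it differs from compound 3 by the change (4-chlorophenyl in place of 3-cyanophenyl on an amide-type nitrogen).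

Within the data shown here, the only measured step that touches this change is the exchange of chloro for cyano on an aromatic carbon, no change at the digits printed from compound 1 to compound 2 (within the scatter), which left the number unmoved. Among the measured compounds shown here, that step kept the position of the substituent, whereas the move from compound 3 to compound 4 also shifts it, a part of the change for which no measured pair is available. On the evidence of the step from compound 1 to compound 2, no change beyond the scatter is expected for the step of a 1.0-fold higher number from compound 3 to compound 4 (0.01 log units; within the scatter). For compound 4 in this assay the estimate is therefore 9500 nM, with a range from 4000 nM to 23000 nM.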

Compound 4, half-maximal effective concentration: > 30000 nM
Compound 4: a limit, no number (the forecaster's own chance of this, stated with the estimate: 10%); middle value at least 3.1-fold (0.49 log units) from the limit.
By their numbers in this assay, from the lowest: compounds 3, 1 and 2 (each within the scatter of the next). At a limit, above all of these: compound 4.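

In this assay, the exchange on the amide-type nitrogen gives an at least 3.2-fold higher number from compound 3 to compound 4 (0.50 log units; beyond the scatter), so the aryl group at this place is not free to vary without consequence. The earlier step alone, no change at the digits printed from compound 1 to compound 2 (within the scatter), gave no sign of this: there chloro replaced the nitrile and the number stayed put, whereas 4-chlorophenyl in place of 3-cyanophenyl changes the substituent and also shifts where it sits on the ring, and this combined change is the first among the compounds shown to move the read-out beyond the scatter. For compound 4 the reading > 30000 nM is a limit of the assay and not a number: the limit of > 30000 nM in this assay, at which 1 of the 4 values shown sits.

The compounds shown leave open whether the chloro group or the shift on the ring carries the step, as no single pair with the carbonyl linker separates the two parts of the change. They also leave open how an amine or a carboxylic acid in place of the chloro of compound 4 would read in this assay.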